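This account rests on a few compounds, and the source may have more. Where it says the series, first, only, none or still open, it means among the compounds named here.

Measured so far:
Compound 1, `Cc1ccc(-c2nn(-c3ccc(Cl)cc3)cc2-c2cc(-c3ccc(Cl)cc3)[nH]c2-c2ccc(F)cc2)cc1`: 21%
Compound 2, `COc1ccc(-c2[nH]c(-c3ccc(Cl)cc3)cc2-c2cn(-c3ccc(Cl)cc3)nc2-c2ccc(C)cc2)cc1`: 21.3%
Compound 3, `Cc1ccc(-c2nn(-c3ccc(S(N)(=O)=O)cc3)cc2-c2cc(-c3ccc(Cl)cc3)[nH]c2-c2ccc(F)cc2)cc1`: 66.7%

In a functional assay on the whole organism (strain Wistar albino) for inhibition, with Rattus norvegicus as the target, read by paw edema, with stated times of 1 h and 3 h, at a dose of 0.32 mmol/kg by the intraperitoneal route (a higher number here means more inhibition at the dose given (going by the name of the read-out), a lower number less inhibition), compound 3 stands highest of the three. Going by the values given here, its gap to compound 1 is the one measured step that carries weight: a number 45.7 percentage points higher from compound 1 to compound 3 (beyond the scatter). Compound 2 lies no nearer; its value and that of compound 3 differ by about the same amount, beyond the scatter. Compound 1 and compound 2, on the other hand, give numbers that cannot be told apart: a number 0.3 percentage points higher from compound 1 to compound 2 (within the scatter).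

The next compound, compound 4, `COc1ccc(-c2[nH]c(-c3ccc(Cl)cc3)cc2-c2cn(-c3ccc(S(N)(=O)=O)cc3)nc2-c2ccc(C)cc2)cc1`, keeps the sulfamoyl group of compound 3 and changes only one place: methoxy in place of fluoro on an aromatic carbon. The same change has already been measured once, from compound 1 to compound 2, where it left this assay unmoved within the scatter. Compound 4 is therefore expected to stay where compound 3 stands, with the step of a number 0.7 percentage points lower from compound 3 to compound 4 (within the scatter) judged to be nothing beyond the scatter. Among the compounds with values here, the estimate for compound 4 in this assay is 66%, with a likely range from 52% to 78%; only one comparison supports it, so the range is kept wide.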

Compound 4, a percentage reported as inhibition, in the whole organism at one dose (the size of the read-out at that dose, not a potency): 34.2%
Compound 4: the middle estimate sits 31.8 percentage points above what was measured, outside the stated range (below it).
By their numbers in this assay, from the lowest: compounds 1 and 2 (each within the scatter of the next); then compound 4; then compound 3.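

In this assay, the change from 4-fluorophenyl to 4-methoxyphenyl proves not to be neutral in general, since with the sulfamoyl group present it gives a number 32.5 percentage points lower from compound 3 to compound 4 (beyond the scatter), so the silence of this change on the chloro core holds for that core alone: the same change on two cores in this assay, a number 0.3 percentage points higher (within the scatter) from compound 1 to compound 2 and a number 32.5 percentage points lower (beyond the scatter) from compound 3 to compound 4, 32.8 percentage points apart, beyond the scatter of two such steps

The sulfamoyl gain depends on its partner in the same way, being much smaller with 4-methoxyphenyl in the molecule, at a number 12.9 percentage points higher from compound 2 to compound 4 (beyond the scatter), than with 4-fluorophenyl: the same change on two cores in this assay, a number 45.7 percentage points higher (beyond the scatter) from compound 1 to compound 3 and a number 12.9 percentage points higher (beyond the scatter) from compound 2 to compound 4, 32.8 percentage points apart, beyond the scatter of two such steps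

Across these four compounds the two places therefore do not act independently of each other, and the large gain appears in full only where sulfamoyl and 4-fluorophenyl occur together, in compound 3.

From the compounds shown here alone, what remains open is whether this dependence belongs to the methoxy group itself or would also appear with a hydroxyl, a dimethylamino group or a plain phenyl ring in place of the fluoro. Going by these compounds, it is equally open whether a methylsulfonyl group or a carboxylic acid in place of the sulfamoyl would show the same dependence on its partner.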